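Swapping the Sulfonyl Ring: From Furan to Fluoropyridine

The compounds below may be only part of what the source reports. "The series", "measured", "known", "first", "only" and "open" are said of these compounds alone.

Measured so far:
- compound 1, `CNCc1cn(S(=O)(=O)c2ccco2)c(-c2cccnc2F)c1F`, 26 ng.h/mL
- compound 2, `CNCc1cn(S(=O)(=O)c2ccoc2)c(-c2cccnc2F)c1F`, 41 ng.h/mL
- compound 3, `CNCc1cn(S(=O)(=O)c2cncc(Cl)c2)c(-c2cccnc2F)c1F`, "not determined" (no result reported)

In an ADME assay on the whole organism (plasma, Rattus norvegicus, strain Sprague-Dawley) for pharmacokinetics, read by LC-MS, using cassette dosing, at a dose of 0.2 mg/kg by the intravenous route (on this read-out higher numbers stand for higher exposure at the dose given and lower numbers for lower exposure), compound 1 gives 26 ng.h/mL, the lowest of the two numbers available, with compound 2 at 41 ng.h/mL. Within the data shown here, the only measured step is a 1.6-fold higher number from compound 1 to compound 2 (0.20 log units; within the scatter), and it does not separate the two compounds. Compound 3 carries a different six-membered ring on the same sulfonyl sulfur, but for it no number was reported in this assay.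

Compound 4, `CNCc1cn(S(=O)(=O)c2cncc(F)c2)c(-c2cccnc2F)c1F`, differs from compound 1 at the same position: 5-fluoropyridin-3-yl in place of furan-2-yl on a sulfonyl sulfur. Among the measured compounds shown here, the one step that bears on this place, a 1.6-fold higher number from compound 1 to compound 2 (0.20 log units; within the scatter), exchanged one five-membered ring for another and stayed within the scatter; no step exchanges a five-membered ring for a six-membered one, and compound 3, the nearest case, has no number. The expectation therefore rests on compound 1 alone.

Compound 4 is estimated at 30 ng.h/mL in this assay, within a range of 10 ng.h/mL to 90 ng.h/mL. This expectation amounts to a 1.2-fold higher number from compound 1 to compound 4 (0.06 log units; within the scatter), that is, no step beyond the scatter.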

Compound 4, area under the concentration-time curve: 38 ng.h/mL
Compound 4: middle estimate off by 1.3-fold (0.10 log units), on the low side, and the stated range covers the measured number.
By their numbers in this assay, from the lowest: compounds 1, 4 and 2 (each within the scatter of the next).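

Among these compounds, until now, the only comparison at this position swapped one five-membered ring for another. Compound 4 extends it to a six-membered aromatic ring carrying fluorine: in this assay, replacing furan-2-yl with 5-fluoropyridin-3-yl on the sulfonyl sulfur gives a 1.5-fold higher number from compound 1 to compound 4 (0.16 log units; within the scatter), and replacing furan-3-yl with it gives a 1.1-fold lower number from compound 2 to compound 4 (0.03 log units; within the scatter). At this position, then, neither the change of ring size nor the choice between these three aromatic groups separates the compounds on this read-out, and no supporting measurement is available to explain this result.

From the compounds shown here alone, these three groups are all aromatic rings, so it remains open whether a saturated ring such as piperidine, a plain alkyl chain, or a ring bearing an amine or a carboxylic acid on the sulfonyl sulfur would move the exposure beyond the scatter. Going by these compounds, it also remains open whether exposure would respond to a change elsewhere on the core, such as replacing the methylamino group or the 2-fluoropyridine-type ring shared by these compounds.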